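The source may report more compounds than this note shows. Statements on the series, on what has been measured and on what is new or still open speak of the compounds shown alone.

Measured compounds:
compound 1 `O=C(Nc1cccc(-n2cc(-c3ccncc3)c(-c3cc(O)cc(Cl)c3)n2)c1)Nc1ccc(Cl)c(Cl)c1` gives 97% in a functional assay on NCI-H23 cells (Homo sapiens) for inhibition, read by sulforhodamine B assay, with a stated time of 48 h, tested at 0.1 uM; a lower number here means a stronger effect, a higher number a weaker effect of the compound at the concentration tested
compound 2 `COc1cc(Cl)cc(-c2nn(-c3cccc(NC(=O)Nc4cc(C(F)(F)F)cc(C(F)(F)F)c4)c3)cc2-c2ccncc2)c1` gives 95% in this assay
compound 3 `COc1cc(Cl)cc(-c2nn(-c3cccc(NC(=O)Nc4ccc(Cl)c(Cl)c4)c3)cc2-c2ccncc2)c1` gives 93% in this assay

Compound 3 stands among its neighbours with a number that lies within the scatter of both compound 2 and compound 1, so the three are not separable on these values. Going by the values given here, the one step with a single change, a number 4 percentage points lower from compound 1 to compound 3 (within the scatter), is within the scatter. Compound 2 and compound 3, which differ in the aryl group on the urea, also give values within the scatter of each other, though no single-step comparison of them is given.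

Compound 4 `COc1cc(Cl)cc(-c2nn(-c3cccc(NC(=O)c4cccc(C(F)(F)F)c4)c3)cc2-c2ccncc2)c1` is not yet measured. It differs from compound 3 in one place: 3-(trifluoromethyl)phenyl in place of (3,4-dichlorophenyl)amino on a carbonyl carbon. Among the compounds with values here, no measured step involves this change of the urea into an amide, so nothing in the measured steps bears directly on it. Since all three measured values are close to one another, and the urea aryl change between compound 2 and compound 3 shows no shift beyond the scatter, compound 4 is expected to stay near compound 3, with a step of a number 3 percentage points lower from compound 3 to compound 4 (within the scatter) that is not expected to exceed the scatter. Compound 4 is therefore estimated at 90%, in a range from 72% to 100%.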

Compound 4, a percentage reported as activity, at one concentration (the size of the read-out at that concentration, not a potency): 97%
Estimate against measurement, compound 4: 7 percentage points below; measured number inside the range.
By their numbers in this assay, from the lowest: compounds 3, 2, 1 and 4 (each within the scatter of the next).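

In this assay, putting 3-(trifluoromethyl)phenyl in place of (3,4-dichlorophenyl)amino on a carbonyl carbon, which turns the urea into an amide, gives a number 4 percentage points higher from compound 3 to compound 4 (within the scatter). This is the first step shown at this place to remove the nitrogen of the urea, and with it the 1 hydrogen-bond donor of the leaving group, yet the read-out at this single concentration does not separate the two compounds. Nothing available here explains this result.

The compounds shown leave open how a group without an aromatic ring on the carbonyl carbon, such as a morpholine or a longer alkyl chain, or a sulfonamide in place of the amide, would read in this assay. From the compounds shown here alone, it also remains open whether compound 3 and compound 4 would separate at another concentration, as one concentration gives the size of the read-out and not a potency.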